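The compounds below may be only part of what the source reports. "The series", "measured", "known", "first", "only" and "open" are said of these compounds alone.

In an ADME assay on CHO cells (Cricetulus griseus) for cytotoxicity, read by MTT assay (on this read-out lower numbers stand for higher toxicity in this test and higher numbers for lower toxicity in this test), compound 1 `CN1CCN(C2CCN(c3nccc4[nH]c(-c5ccc(F)c(F)c5)nc34)CC2)CC1` gives 5000 nM. Compound 2 `CN1CCN(CC2CCN(c3nccc4[nH]c(-c5ccc(F)c(F)c5)nc34)CC2)CC1` gives 7400 nM, which leaves the two level: a 1.5-fold higher number from compound 1 to compound 2 (0.17 log units; within the scatter). Compound 3 `CN1CCN(C(=O)C2CCN(c3nccc4[nH]c(-c5ccc(F)c(F)c5)nc34)CC2)CC1` reads > 50000 nM, which is a limit of the assay and not a number. Compound 4 `CN1CCN(C2CCN(c3nccc4[nH]c(-c5cccc(C#N)c5)nc34)CC2)CC1` keeps the saturated side of compound 1 and carries 3-cyanophenyl in place of 3,4-difluorophenyl on an aromatic carbon. Within the data shown here, no measured step changes that aromatic group. All three changed the group on a saturated ring carbon, and the larger ones, an at least 10-fold higher number from compound 1 to compound 3 (1.00 log units; beyond the scatter) and an at least 6.7-fold higher number from compound 2 to compound 3 (0.82 log units; beyond the scatter), brought in a carbonyl that compound 4 does not have. With only indirect support, no change beyond the scatter is expected, and the expected step is a 1.2-fold higher number from compound 1 to compound 4 (0.08 log units; within the scatter). For compound 4 the estimated value is 6000 nM, with an expected range of 2000 nM to 18000 nM.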

Compound 4, half-maximal cytotoxic concentration: 16000 nM
Compound 4: middle estimate off by 2.7-fold (0.43 log units), on the low side, and the stated range covers the measured number.
By their numbers in this assay, from the lowest: compounds 1 and 2 (each within the scatter of the next); then compound 4. At a limit, above all of these: compound 3.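

In this assay the group on the aromatic carbon between two ring nitrogen atoms now has a measured step of its own, with the saturated side held as in compound 1 (a 3.2-fold higher number from compound 1 to compound 4 (0.51 log units; beyond the scatter)). The number therefore moves beyond the scatter without any change on the saturated ring carbon and without a carbonyl. Nothing measured here bears on why this exchange of 3,4-difluorophenyl for 3-cyanophenyl has this effect.

On these data alone, whether a carboxylic acid or a primary amide in place of the nitrile would move the number further remains open. Also open, as far as these compounds go, is whether 3-cyanophenyl gives a similar step alongside the (4-methylpiperazin-1-yl)methyl group of compound 2.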